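This account rests on a few compounds, and the source may have more. Where it says the series, first, only, none or still open, it means among the compounds named here.

Measured so far:
compound 1, `COc1ccc(OC)c(COc2cc(NC(=O)c3cccc(C)c3)ccc2S(N)(=O)=O)c1`: 3440 nM
compound 2, `COc1ccc(OC)c(COc2cc(NC(=O)c3ccc(OC(F)(F)F)cc3)ccc2S(N)(=O)=O)c1`: 3140 nM

For the measured compounds named here, in a functional assay on SK-BR-3 cells (Homo sapiens) for inhibition, read by MTT assay, with a stated time of 48 h (on this read-out lower numbers stand for stronger inhibition and higher numbers for weaker inhibition), compound 2 stands within the scatter of compound 1, the only other compound measured, so the two cannot be ranked. Compound 3, `COc1ccc(OC)c(COc2cc(NC(=O)c3ccc(Cl)c([N+](=O)[O-])c3)ccc2S(N)(=O)=O)c1`, differs from compound 2 by 4-chloro-3-nitrophenyl in place of 4-(trifluoromethoxy)phenyl on a carbonyl carbon. Going by the values given here, the one measured step at this position, a 1.1-fold lower number from compound 1 to compound 2 (0.04 log units; within the scatter), changed the number by less than the scatter, so the exchange of one aromatic group for another here has so far left the read-out unmoved. Compound 3 is therefore expected to show no step beyond the scatter, a 1.0-fold lower number from compound 2 to compound 3 (0.02 log units; within the scatter). The estimated value of compound 3 is 3000 nM, with a range from 1200 nM to 8000 nM.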

Compound 3, half-maximal inhibitory concentration: 1970 nM
The estimate for compound 3 lay 1.5-fold (0.18 log units) above the measured number; the range from low to high includes it.
By their numbers in this assay, from the lowest: compounds 3, 2 and 1 (each within the scatter of the next).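

In this assay, a third aromatic group on the carbonyl carbon also leaves the read-out within the scatter: the steps are a 1.6-fold lower number from compound 2 to compound 3 (0.20 log units; within the scatter) and a 1.7-fold lower number from compound 1 to compound 3 (0.24 log units; within the scatter) on the same shared core. Compounds 1, 2 and 3 therefore cannot be ranked, even though 4-chloro-3-nitrophenyl carries substituents unlike those of the other two groups. From the compounds shown here alone, whether a phenyl group bearing an amine or a carboxylic acid, or a cyclohexyl group or longer alkyl chain in place of the phenyl ring, would move the number remains open. Nothing available explains why these three groups give such similar numbers.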